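This account rests on a few compounds, and the source may have more. Where it says the series, first, only, none or still open, it means among the compounds named here.

In an ADME assay on Vero cells (Chlorocebus sabaeus) for cytotoxicity, with a stated time of 72 h (on this read-out lower numbers stand for stronger inhibition and higher numbers for weaker inhibition), compound 2, `O=[N+]([O-])c1cn2c(n1)OCC(COc1ccc(-c3ccc(C(F)(F)F)cc3)cc1)C2`, gives only a limit of the assay, > 128000 nM. Compound 1, `O=[N+]([O-])c1cn2c(n1)OCC(COc1ccc(OC(F)(F)F)cc1)C2`, likewise gives only a limit in this assay, > 128000 nM. Among the measured compounds shown here, the one measured step, a step that the two limits leave unreadable from compound 1 to compound 2, has no readable size, since the limit of > 128000 nM in this assay, at which 2 of the 2 values shown sit, holds both of the values shown. Compound 3, `O=[N+]([O-])c1cn2c(n1)OCC(COc1ccc(-c3ccc(F)cc3)cc1)C2`, differs from compound 2 by fluoro in place of trifluoromethyl on an aromatic carbon. For the measured compounds named here, no measured step bears directly on this change, and the single recorded step, running from one limit to another, gives no size at all. The expectation for compound 3 can rest only on the fact that both measured compounds sit at the limit of > 128000 nM in this assay, at which 2 of the 2 values shown sit. The expected step that the limit leaves unreadable from compound 2 to compound 3 is therefore none beyond the scatter. Compound 3 is estimated to come out at 200000 nM, between 100000 nM and 500000 nM, and most likely again as a limit rather than a number.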

Compound 3, half-maximal inhibitory concentration: > 128000 nM
Compound 3 ended at the assay's limit; the forecaster's own chance of this, stated with the estimate: 85%; the middle value does not contradict the limit.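

No size can be read for any step among compound 1, compound 2 and compound 3 in this assay, as all three give only a limit of the assay: the limit of > 128000 nM in this assay, at which 3 of the 3 values shown sit. The compounds shown leave open whether trifluoromethoxy, 4-(trifluoromethyl)phenyl and 4-fluorophenyl differ at all in this assay.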